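The source may report more compounds than this note shows. Statements on the series, on what has been measured and on what is new or still open speak of the compounds shown alone.

Three compounds sharing one core were tested in an assay on isolated protein for displacement of a labelled ligand from metabotropic glutamate receptor 5 (Homo sapiens), with a stated time of 60 min, tested at 1 uM; on this read-out higher numbers stand for more inhibition at the one concentration tested (going by the name of the read-out) and lower numbers for less inhibition. Compound 1 `NC(=O)C1CCN(c2c(S(=O)(=O)c3ccccc3)cnc3ccccc23)CC1` gives 24.8%. Compound 2 `CC1CCN(c2c(S(=O)(=O)c3ccc(F)cc3)cnc3cc(Cl)ccc23)CC1` gives 91%. Compound 3 `Cc1ccc(S(=O)(=O)c2cnc3ccc(C)cc3c2N2CCC(C)CC2)cc1` gives 82%. Compound 2 carries the highest of the three numbers, yet its reading and that of compound 3 sit within the usual scatter of repeated measurements, so the two cannot be told apart. The gap between compound 2 and compound 1 lies well beyond that scatter.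

Compound 4 `CC1CCN(c2c(S(=O)(=O)c3ccc(F)c(F)c3)cnc3cc(Cl)ccc23)CC1` has not yet been measured. Compared with compound 2, it differs in one place:
fluoro in place of hydrogen on an aromatic carbon
Among the measured compounds shown here, no pair of measured compounds shows this exact change, so no measured step exists to lean on.

Because compound 2 already gives 91% in this assay, there is little room for a larger number, and a single added fluoro is expected to shift the reading by no more than the scatter, in either direction or not at all. Compound 4 is therefore expected to give about 88%, between 75% and 96%. The expected step from compound 2 to compound 4 is a number 3 percentage points lower from compound 2 to compound 4 (within the scatter), within the scatter.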

Compound 4, a percentage reported as inhibition, at one concentration (the size of the read-out at that concentration, not a potency): 90%
Estimate against measurement, compound 4: 2 percentage points below; the range from low to high includes it.
By their numbers in this assay, from the lowest: compound 1; then compounds 3, 4 and 2 (each within the scatter of the next).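

In this assay, the change from 4-fluorophenyl to 3,4-difluorophenyl comes to a number 1 percentage points lower from compound 2 to compound 4 (within the scatter), so a fluoro on this aromatic carbon, ortho to a fluoro group and meta to a large group, leaves no difference that can be read. Among the compounds shown here, this is the first view of a single change, as no two earlier compounds differed in only one place, although compound 2 and compound 4 both read so near the top of the percentage scale that a gain would be hard to see. Nothing measured here offers an explanation for this result.

From the compounds shown here alone, whether this carbon would keep the reading with a methoxy, an amine or a carboxylic acid remains open. A reading at one concentration also leaves open whether compound 2 and compound 4 would separate at lower concentrations.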